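This account rests on a few compounds, and the source may have more. Where it says the series, first, only, none or still open, it means among the compounds named here.

Compound 1 `COc1cc(-c2nn(-c3cccc(NC(=O)c4ccc(Cl)c(C(F)(F)F)c4)c3)cc2-c2ccncc2)ccc1Cl` gives 7860 nM in a functional assay on HCC 2998 cells (Homo sapiens) for inhibition, read by sulforhodamine B assay, with a stated time of 48 h; a lower number here means a stronger inhibitor of growth, a higher number a weaker inhibitor of growth.
Compound 2 `COc1cc(-c2nn(-c3cccc(NC(=O)c4cccc(C(F)(F)F)c4)c3)cc2-c2ccncc2)ccc1Cl` gives 2240 nM.
Compound 3 `COc1cc(-c2nn(-c3cccc(NC(=O)Nc4ccc(Cl)c(C(F)(F)F)c4)c3)cc2-c2ccncc2)ccc1Cl` gives 1550 nM.

Among these three, compound 1 has the highest number: compound 2 lies a 3.5-fold lower number from compound 1 to compound 2 (0.55 log units; beyond the scatter) and compound 3 lies a 5.1-fold lower number from compound 1 to compound 3 (0.71 log units; beyond the scatter), both beyond the scatter. Compound 4 `COc1cc(-c2nn(-c3cccc(NC(=O)c4ccccc4)c3)cc2-c2ccncc2)ccc1Cl` differs from compound 1 in one place: phenyl in place of 4-chloro-3-(trifluoromethyl)phenyl on a carbonyl carbon. Within the data shown here, the only measured step that bears on this change is the one from compound 1 to compound 2, where removal of the chloro alone gave a 3.5-fold lower number from compound 1 to compound 2 (0.55 log units; beyond the scatter). Among the measured compounds shown here, compound 4 goes further and strips the trifluoromethyl as well, for which no measured pair gives guidance. For the measured compounds named here, the one relevant step points downward, so the number for compound 4 is expected to fall below that of compound 1, though whether the second removal adds, cancels or reverses the gain cannot be read from these compounds. Compound 4 is therefore expected to show a 3.1-fold lower number from compound 1 to compound 4 (0.50 log units; beyond the scatter), with a wide range. The estimate for compound 4 is 2500 nM, between 800 nM and 8000 nM.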

Compound 4, concentration for 50% growth inhibition: 2320 nM
Compound 4: the middle estimate sits 1.1-fold (0.03 log units) above what was measured; the range from low to high includes it.
By their numbers in this assay, from the lowest: compounds 3, 2 and 4 (each within the scatter of the next); then compound 1.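

Taking away the trifluoromethyl once the chloro is already gone changes nothing measurable, with a 1.0-fold higher number from compound 2 to compound 4 (0.02 log units; within the scatter), so that group shows no separate effect on the number in this pair. Removing both groups gives a 3.4-fold lower number from compound 1 to compound 4 (0.53 log units; beyond the scatter), a step of about the same size as a 3.5-fold lower number from compound 1 to compound 2 (0.55 log units; beyond the scatter), and only compound 1, which carries the 4-chloro-3-(trifluoromethyl)phenyl directly on the carbonyl carbon, stands apart from the others. The plain phenyl also stays level with the (4-chloro-3-(trifluoromethyl)phenyl)amino group, at a 1.5-fold higher number from compound 3 to compound 4 (0.18 log units; within the scatter), and nothing available here explains these steps.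

The compounds shown leave open how a phenyl carrying the chloro without the trifluoromethyl would read. They also do not show what an amine or a carboxylic acid on that ring, or a cyclohexyl in place of the phenyl, would do.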